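Thiophene for trifluoromethylphenyl in an H2 agonist series

This account rests on a few compounds, and the source may have more. Where it says the series, first, only, none or still open, it means among the compounds named here.

Measured compounds:
Compound 1, `N=C(NCCCc1c[nH]cn1)NCCC(c1ccc(Br)cc1)c1ccccn1`: 7.48
Compound 2, `N=C(NCCCc1c[nH]cn1)NCCC(c1cccc(C(F)(F)F)c1)c1ccccn1`: 7.43

In a functional assay on cardiac atrium for agonist activity at histamine H2 receptor (Cavia porcellus) (a higher number here means a more potent compound, by a factor of ten per unit of this negative logarithm, a lower number a less potent compound), compound 2 has the lower of the two numbers, and compound 1 sits within the scatter of it. The step of a number 0.05 log units lower from compound 1 to compound 2 (within the scatter) shows that exchanging one aryl group for another on that chain carbon changed little. Compound 3, `N=C(NCCCc1c[nH]cn1)NCCC(c1ccccn1)c1cccs1`, carries the change (thiophen-2-yl in place of 3-(trifluoromethyl)phenyl on a saturated chain carbon bound to an aromatic carbon and a saturated chain carbon). Because that aryl swap gave a number 0.05 log units lower from compound 1 to compound 2 (within the scatter), no step beyond the scatter is expected from compound 2 to compound 3 in this assay, estimated as a number 0.13 log units lower from compound 2 to compound 3 (within the scatter). Compound 3 is therefore expected to give about 7.3, between 6.7 and 7.9.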

Compound 3, negative logarithm of the half-maximal effective concentration: 7.16
Compound 3: middle estimate off by 0.14 log units, on the high side, within the range that was stated.
By their numbers in this assay, from the lowest: compounds 3, 2 and 1 (each within the scatter of the next, the first and the last beyond it).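

Thiophen-2-yl on the saturated chain carbon gives a number 0.27 log units lower from compound 2 to compound 3 (within the scatter) in this assay and so shows that this position tolerates a five-membered aromatic ring of 5 heavy atoms where a six-membered ring group of 10 heavy atoms left. Set against 4-bromophenyl, the same ring gives a number 0.32 log units lower from compound 1 to compound 3 (beyond the scatter) and this is the first step at this position to pass the scatter, though only modestly. Nothing shown here accounts for either step. Going by these compounds, how a furan-2-yl ring or a primary amine would fare on this carbon remains open.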